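The source may hold more compounds than are shown below. What is called first, only, known or untested is meant among the compounds shown, and "the series" means these compounds.

Measured in a physicochemical assay for lipophilicity, measured as octanol-water partition; on this read-out higher numbers stand for higher lipophilicity and lower numbers for lower lipophilicity:
- compound 1 `CC1=C(C(=O)OCc2cccnc2)C(c2ccccc2[N+](=O)[O-])C2=C(CCCC2=O)N1` gives 1.51
- compound 2 `CC1=C(C(=O)OCc2ccccn2)C(c2ccc(O)cc2)C2=C(CCCC2=O)N1` gives 1.58

Compound 2 at 1.58 stands within the scatter of compound 1 at 1.51 on this read-out, so the two numbers set no order between them. Going by the values given here, the two compounds also differ in more than one place, and the series so far offers no single-change step to work from.

Compound 3 `CC1=C(C(=O)OCc2ccccn2)C(c2cccc([N+](=O)[O-])c2)C2=C(CCCC2=O)N1` has not been measured. Its change from compound 2 is 3-nitrophenyl in place of 4-hydroxyphenyl on a saturated ring carbon with 3-nitrophenyl in place of 4-hydroxyphenyl on a saturated ring carbon.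

Among the compounds with values here, a modest rise in this assay is expected, though no measured step supports its size. Compound 1 also carries a nitro group on its phenyl ring and gives 1.51 here, which offers no sign of a large step and argues for a wide range. The expected change is a number 0.27 log units higher from compound 2 to compound 3 (within the scatter) as an estimate only. Compound 3 is estimated at 1.85 as the middle value, with an expected range from 1.4 to 2.3 in this measurement.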

Compound 3, partition coefficient: 1.88
For compound 3 the middle estimate is 0.03 log units below the measured one, and the stated range covers the measured number.
By their numbers in this assay, from the lowest: compounds 1, 2 and 3 (each within the scatter of the next, the first and the last beyond it).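

In this assay the series now has its first single-change step, on a saturated ring carbon of the shared core: 3-nitrophenyl in place of 4-hydroxyphenyl reads as a number 0.30 log units higher from compound 2 to compound 3 (within the scatter) and so sets no order between the two compounds. This exchange takes away the hydrogen-bond donor of 4-hydroxyphenyl and brings in a larger group with more hydrogen-bond acceptors, yet the two numbers remain within the scatter of each other, so this one pair gives no sign that the position responds to the exchange in this measurement. No measured information on the compounds bears on the size of this step.

Compound 1 differs from compound 2 and from compound 3 in more than one place, so it adds no further reading at this position, and the separate parts played by the loss of the hydroxy group and the arrival of the nitro group remain unresolved. An unsubstituted phenyl, or a phenyl carrying an amine or a carboxylic acid, at the same ring carbon would show whether a wider range of groups separates beyond the scatter.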